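Swapping Trifluoromethyl for Methyl in a Growth Inhibitor

A few compounds are considered here, and "the series" means these few. Any claim that something is new, unique, unknown or untested is made for them only; others in the source may bear on it.

Measured in a functional assay on NCI-H460 cells (Homo sapiens) for inhibition; a lower number here means a stronger inhibitor of growth, a higher number a weaker inhibitor of growth:
- Compound 1 `Cc1cc(-c2nc3c(F)cccc3s2)ccc1N`: 1000 nM
- Compound 2 `Nc1ccc(-c2nc3ccccc3s2)cc1C(F)(F)F`: 14500 nM

Among the measured compounds shown here, only two measurements are available so far. Compound 2, at 14500 nM, has the higher number of the two, which makes it the weaker inhibitor of growth, and its gap to compound 1 lies beyond the scatter.

The next compound to be tested is compound 3 `Cc1cc(-c2nc3ccccc3s2)ccc1N`. It keeps the core of compound 2 and changes one group: methyl in place of trifluoromethyl on an aromatic carbon. The new methyl sits ortho to an amino group.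

For the measured compounds named here, no measured pair isolates this swap, so the evidence is thin. The best guide is compound 1, which also carries methyl in that place and gives 1000 nM, although it differs from compound 3 elsewhere on the core. A sizeable move in this assay towards a lower number, beyond the scatter, is therefore expected. The expected change is a 15-fold lower number from compound 2 to compound 3 (1.16 log units; beyond the scatter). For compound 3 the estimated value is 1000 nM, with an expected range from 150 nM to 6000 nM.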

Compound 3, concentration for 50% growth inhibition: 29500 nM
The estimate for compound 3 lay 30-fold (1.47 log units) below the measured number, and the stated range ends below it.
By their numbers in this assay, from the lowest: compound 1; then compound 2; then compound 3.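

In this assay, with the rest of the structure held constant, methyl in place of trifluoromethyl ortho to an amino group gives a 2.0-fold higher number from compound 2 to compound 3 (0.31 log units; beyond the scatter). This modest step runs in the weaker direction, so methyl at this position does not account for the low number of compound 1, even though compound 1 also carries it. The large change comes from the other single difference: hydrogen in place of fluoro on an aromatic carbon gives a 30-fold higher number from compound 1 to compound 3 (1.47 log units; beyond the scatter), which ties the stronger growth inhibition among these compounds to that fluoro on the shared core, and nothing measured here bears on why either step occurs.

As far as these compounds go, whether fluoro on the core would lower the number to the same extent with trifluoromethyl in place of methyl remains open. From the compounds shown here alone, it is also open how hydrogen, chloro, methoxy or a longer chain such as ethyl would compare with methyl and trifluoromethyl ortho to an amino group, and so whether this position matters much for growth inhibition.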